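The compounds below may be only part of what the source reports. "The series", "measured", "known", "first", "only" and "open" are said of these compounds alone.

Measured in a functional assay on HFF cells (Homo sapiens) for cytotoxicity; on this read-out higher numbers stand for weaker inhibition and lower numbers for stronger inhibition:
- Compound 1 `O=C1/C(=C/c2ccccc2F)SC(=S)N1NS(=O)(=O)c1ccccc1`: > 100000 nM
- Compound 2 `O=C1/C(=C/c2ccc(Cl)c(F)c2)SC(=S)N1NS(=O)(=O)c1ccccc1`: > 100000 nM
- Compound 3 `O=C1/C(=C/c2ccc(F)cc2F)SC(=S)N1NS(=O)(=O)c1ccccc1`: > 100000 nM

Each of these entries is a limit and not a number. The three compounds share one reading: the limit of > 100000 nM in this assay, at which 3 of the 3 values shown sit. Compound 3 therefore has no exact position, and its entry of > 100000 nM is a limit.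

Compound 4 `O=C1/C(=C/c2cc(F)c(F)cc2F)SC(=S)N1NS(=O)(=O)c1ccccc1` differs from compound 3 by fluoro in place of hydrogen on an aromatic carbon. This is fluoro in place of hydrogen on an aromatic carbon, turning 2,4-difluorophenyl into 2,4,5-trifluorophenyl.

Among the measured compounds shown here, the closest precedent is a step that the two limits leave unreadable from compound 1 to compound 3, which is the same kind of replacement. The other two measured changes, a step that the two limits leave unreadable from compound 1 to compound 2 and a step that the two limits leave unreadable from compound 2 to compound 3, also alter the substituted phenyl group. None of the three gives a size, so none supports a direction. In this assay, no change beyond the usual scatter is therefore expected, and the expected step is a number no higher from compound 3 to compound 4 (the limit leaves the size open). Compound 4 is estimated at 100000 nM, with an expected range from 50000 nM to 200000 nM.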

Compound 4, half-maximal inhibitory concentration: > 100000 nM
Compound 4: only a limit was reported; the forecaster's own chance of this, stated with the estimate: 85%; the middle value sits exactly at the limit.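

In this assay compound 4 gives > 100000 nM, which is a limit. Among the compounds shown here, no step from compound 1, compound 2 or compound 3 to compound 4 can be read, because all four compounds share one reading: the limit of > 100000 nM in this assay, at which 4 of the 4 values shown sit. These compounds leave open whether any of the phenyl changes shifts the read-out at all.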